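Thiophen-2-yl Replaced by Dimethylcarbamoyl: Expected Lipophilicity Drop

The source may hold more compounds than are shown below. What is called first, only, known or untested is meant among the compounds shown, and "the series" means these compounds.

Three measured compounds share one core and differ only in the group on the amine nitrogen in a ring. In a physicochemical assay for lipophilicity, using the shake flask method, measured as octanol-water partition, at pH 7.4 (on this read-out lower numbers stand for lower lipophilicity and higher numbers for higher lipophilicity), compound 1 `CNC(=O)CN1CCC(c2cc3c(-c4ccc(=O)n(C(C)C)c4)ccnc3[nH]2)CC1` gives 2.2, compound 2 `CC(=O)N1CCC(c2cc3c(-c4ccc(=O)n(C(C)C)c4)ccnc3[nH]2)CC1` gives 2.1, and compound 3 `CC(C)n1cc(-c2ccnc3[nH]c(C4CCN(Cc5cccs5)CC4)cc23)ccc1=O` gives 3.4, the highest of the three. Compound 4 `CC(C)n1cc(-c2ccnc3[nH]c(C4CCN(CC(=O)N(C)C)CC4)cc23)ccc1=O` is not yet measured and differs from compound 3 by dimethylcarbamoyl in place of thiophen-2-yl on a saturated chain carbon bound to an amine nitrogen in a ring. Among the measured compounds shown here, two measured steps bear on this change: a number 1.20 log units higher from compound 1 to compound 3 (beyond the scatter) and a number 1.30 log units higher from compound 2 to compound 3 (beyond the scatter), both large, both with the thiophen-2-yl group entering. Compound 4 carries a dimethylcarbamoyl group close in kind to the methylcarbamoyl group of compound 1, whose value of 2.2 suggests a large step back downward is expected: a number 1.00 log units lower from compound 3 to compound 4 (beyond the scatter). Compound 4 is therefore estimated at 2.4, within 2 to 2.8.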

Compound 4, distribution coefficient: 1.9
Beside the measured number, compound 4's estimate is 0.50 log units above it; measured number outside the range, below it.
By their numbers in this assay, from the lowest: compounds 4, 2 and 1 (each within the scatter of the next); then compound 3.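

In this assay dimethylcarbamoyl in place of thiophen-2-yl gives a number 1.50 log units lower from compound 3 to compound 4 (beyond the scatter) and leaves compound 3 alone at the top of the set. The three compounds without thiophen-2-yl do not separate: there is a number 0.20 log units lower from compound 2 to compound 4 (within the scatter) for (dimethylcarbamoyl)methyl in place of acetyl. Methyl in place of hydrogen on an amide-type nitrogen likewise gives a number 0.30 log units lower from compound 1 to compound 4 (within the scatter) and so makes no clear difference here.

As far as these compounds go, whether a phenyl ring, a carboxylic acid or an amine on this saturated chain carbon would match compound 3 or the other three stays open. Nothing shown here explains the size of the large step.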